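Extending the hydroxycarbamoyl chain from compound 2 to compound 3

The source may report more compounds than this note shows. Statements on the series, on what has been measured and on what is new or still open speak of the compounds shown alone.

- compound 1 `O=C(CCCCOC(=O)c1ccc2c(c1)no[n+]2[O-])NO` at 25000 nM here
- compound 2 `O=C(CCCCCOC(=O)c1ccc2c(c1)no[n+]2[O-])NO` at 20600 nM here

In a functional assay on ES2 cells (Homo sapiens) for inhibition, read by MTT assay, with a stated time of 48 h (on this read-out lower numbers stand for stronger inhibition and higher numbers for weaker inhibition), compound 2 gives 20600 nM and so sits within the scatter of compound 1. Compound 3 `O=C(CCCCCCOC(=O)c1ccc2c(c1)no[n+]2[O-])NO` differs from compound 2 by (hydroxycarbamoyl)methyl in place of hydroxycarbamoyl on a saturated chain carbon, five bonds along the chain from an oxygen next to a carbonyl group with (hydroxycarbamoyl)methyl in place of hydroxycarbamoyl on a saturated chain carbon, five bonds along the chain from an oxygen next to a carbonyl group. For the measured compounds named here, the same swap, four bonds along the chain, is the only measured guide, and it gave a 1.2-fold lower number from compound 1 to compound 2 (0.08 log units; within the scatter) as a small step. So no step beyond the scatter is expected in this assay and the estimated step is a 1.2-fold lower number from compound 2 to compound 3 (0.08 log units; within the scatter) as a working figure. For compound 3 the estimated value is 17000 nM with an expected range from 8000 nM to 35000 nM in this measurement.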

Compound 3, half-maximal inhibitory concentration: 5070 nM
Estimate against measurement, compound 3: 3.4-fold (0.53 log units) above; measured number below the stated range.
By their numbers in this assay, from the lowest: compound 3; then compounds 2 and 1 (each within the scatter of the next).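

In this assay, the swap that stayed within the scatter four bonds along the chain has a real effect five bonds along the chain, giving a 4.1-fold lower number from compound 2 to compound 3 (0.61 log units; beyond the scatter). Across the whole series, 2-(hydroxycarbamoyl)ethyl in place of hydroxycarbamoyl gives a 4.9-fold lower number from compound 1 to compound 3 (0.69 log units; beyond the scatter), so lengthening the chain does not change the number evenly across these compounds. Nothing measured here explains this uneven change. The compounds shown leave open whether a longer chain ending in 3-(hydroxycarbamoyl)propyl would lower the number further or raise it again. They also leave open whether a carboxylic acid could replace the hydroxycarbamoyl end at this chain length.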